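The compounds below may be only part of what the source reports. "The series", "measured", "known", "first", "only" and "open" are said of these compounds alone.

Measured compounds:
- Compound 1, `Cn1nnnc1SCC(=O)N/N=C/c1ccc(F)cc1`: 10000000 nM
- Compound 2, `Cn1nnnc1SCC(=O)N/N=C/c1ccc(Cl)cc1`: 2100000 nM
- Compound 3, `Cn1nnnc1SCC(=O)N/N=C/c1cccc(F)c1`: 6320000 nM

All three were tested in an ADME assay on NIH3T3 cells (Mus musculus) for cytotoxicity, read by XTT assay, with a stated time of 24 h; on this read-out lower numbers stand for stronger inhibition and higher numbers for weaker inhibition. Compound 1 gives 10000000 nM. Compound 2 differs from compound 1 by a single change, (chloro in place of fluoro on an aromatic carbon), and this change gave a 4.8-fold lower number from compound 1 to compound 2 (0.68 log units; beyond the scatter). Compound 3 carries the same atoms as compound 1, joined differently; the difference between the two cores is not broken down here. In this assay compound 3 gives 6320000 nM, which lies within the usual scatter of the number for compound 1, so no order between the two can be read from these data.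

Compound 4, `Cn1nnnc1SCC(=O)N/N=C/c1cccc(Cl)c1`, has not yet been measured. It stands to compound 3 as compound 2 stands to compound 1: chloro in place of fluoro on an aromatic carbon. The two changes are the same kind of change, but not the same: in compound 2 the chloro sits para to a large group, in compound 4 meta to a large group. Among the measured compounds shown here, the step from compound 1 to compound 2 is the only measured example of this kind of change, so the expectation rests on it alone. Compound 4 is expected to give 1500000 nM in this assay, somewhere between 500000 nM and 5000000 nM. That estimate means a step of a 4.2-fold lower number from compound 3 to compound 4 (0.62 log units; beyond the scatter), expected to be close to the step of a 4.8-fold lower number from compound 1 to compound 2 (0.68 log units; beyond the scatter).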

Compound 4, half-maximal inhibitory concentration: 7500000 nM
For compound 4 the middle estimate is 5.0-fold (0.70 log units) below the measured one, and the stated range ends below it.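

In this assay, chloro in place of fluoro on an aromatic carbon, meta to a large group, gave a 1.2-fold higher number from compound 3 to compound 4 (0.07 log units; within the scatter), so no order can be read from this pair and the exchange shows no clear effect on this core. Among the compounds shown here, the same exchange on the core of compound 1 gave a clear step, so the result from one core did not carry over to the other, and the two steps differ by more than repeated measurements would explain: the same change on two cores in this assay, a 4.8-fold lower number (0.68 log units; beyond the scatter) from compound 1 to compound 2 and a 1.2-fold higher number (0.07 log units; within the scatter) from compound 3 to compound 4, 5.7-fold (0.75 log units) apart, beyond the scatter of two such steps This shows that, in this series, a step measured for this exchange on one core cannot simply be copied onto a closely related core, but it does not show why the two cores behave differently, and with only two pairs it gives no general rule for other cores.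

The compounds shown carry only fluoro or chloro on the aromatic ring, so they leave open whether a bromo group, a methoxy group or an amine would follow the pattern of the core of compound 1 or that of compound 3. They also leave open whether the gap between the two cores would appear again with any exchange other than this one.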